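The source may hold more compounds than are shown below. What is called first, only, known or untested is meant among the compounds shown, and "the series" means these compounds.

In a functional assay on M21 cells (Homo sapiens) for antiproliferative activity, read by sulforhodamine B assay, with a stated time of 48 h (a higher number here means a weaker inhibitor, a lower number a stronger inhibitor), compound 1 `Cc1ccccc1OS(=O)(=O)c1ccc(N2CCN(C)C2=O)cc1` gives 2900 nM, and compound 2 `COc1ccccc1OS(=O)(=O)c1ccc(N2CCN(C)C2=O)cc1` gives 21000 nM. Compound 3 `CCCN1CCN(c2ccc(S(=O)(=O)Oc3ccccc3C)cc2)C1=O` gives > 100000 nM, which is a limit of the assay and not a number. On these data alone, compound 3 therefore stands at the limit of > 100000 nM in this assay, at which 1 of the 3 values shown sits, and its true value is unknown.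

Compound 4 `CCCN1CCN(c2ccc(S(=O)(=O)Oc3ccccc3OC)cc2)C1=O` carries methoxy in place of methyl on an aromatic carbon, ortho to a large group: methoxy in place of methyl on an aromatic carbon. The same swap has been measured once, giving a 7.2-fold higher number from compound 1 to compound 2 (0.86 log units; beyond the scatter), a modest weakening. The other measured change, ethyl in place of hydrogen on a saturated chain carbon bound to an amide-type nitrogen in a ring, gave an at least 34-fold higher number from compound 1 to compound 3 (1.53 log units; beyond the scatter), a large loss, and compound 4 keeps that chain. One pair is thin evidence, but a modest step toward a higher number is expected, starting from a limit. The estimated step is a step that the limit leaves unreadable from compound 3 to compound 4. For compound 4, the estimated value is 200000 nM, with an expected range from 70000 nM to 800000 nM.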

Compound 4, half-maximal inhibitory concentration: > 100000 nM
Compound 4: only a limit was reported (the forecaster's own chance of this, stated with the estimate: 85%); the middle value lies beyond the limit too.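

In this assay compound 4 gives > 100000 nM, which is a limit of the assay and not a number. Compound 3 also stands at a limit, so the step from methyl to methoxy on this aromatic carbon cannot be read on this core, and the result gives no second size for that change. What the result does add is a second reading of the ethyl-for-hydrogen change on the chain, with an at least 4.7-fold higher number from compound 2 to compound 4 (0.67 log units; beyond the scatter), so the weakening seen among the methyl compounds also appears among the methoxy compounds: the same change on two cores in this assay, an at least 34-fold higher number (1.53 log units; beyond the scatter) from compound 1 to compound 3 and an at least 4.7-fold higher number (0.67 log units; beyond the scatter) from compound 2 to compound 4; the limit leaves it open whether they differ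

On these data alone, the true values of compound 3 and compound 4 remain unknown, and so does whether methoxy weakens activity on this core at all. Also open, as far as these compounds go, is what a group such as chlorine or an amine would do on this aromatic carbon.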